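The source may hold more compounds than are shown below. What is called first, only, known or untested is meant among the compounds shown, and "the series" means these compounds.

Working notes on the stilbene-type series in an assay on HepG2 cells for activation of nuclear factor erythroid 2-related factor 2 (Homo sapiens), read by a luciferase reporter, with a stated time of 5 h; a higher number here means that more compound is needed for the effect, a lower number that less compound is needed.

Compound 1 `COc1cccc(/C=C/c2ccccc2F)c1` gives 3800 nM in this assay. Compound 2 `COc1cccc(/C=C/c2cccc(F)c2)c1` gives 2300 nM, and compound 3 `COc1cccc(/C=C/c2cccc(F)c2)c1OC` gives 1900 nM. Compound 3 has the lowest of the three numbers, but its nearest neighbour compound 2 is within the scatter, and so is compound 1. For the measured compounds named here, the one single-point step on record, a 1.2-fold lower number from compound 2 to compound 3 (0.08 log units; within the scatter), is itself within the scatter, so the addition of the methoxy group on the core of compound 2 is not seen to move the number.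

Compound 4 `COc1cccc(/C=C/c2ccccc2)c1OC` is the next compound. The change from compound 3 is hydrogen in place of fluoro on an aromatic carbon. Going by the values given here, no measured step removes or moves a fluoro group; compounds 1 and 2 carry fluoro at different positions and their two values lie within the scatter of each other, which is all that pair shows. With nothing in the record pointing either way, the step from compound 3 to compound 4 is expected to be a 1.4-fold higher number from compound 3 to compound 4 (0.14 log units; within the scatter), that is within the scatter. Compound 4 is therefore estimated at 2600 nM, with a range of 1200 nM to 5600 nM.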

Compound 4, half-maximal effective concentration: 4700 nM
For compound 4 the middle estimate is 1.8-fold (0.26 log units) below the measured one, and the stated range covers the measured number.
By their numbers in this assay, from the lowest: compounds 3, 2, 1 and 4 (each within the scatter of the next, the first and the last beyond it).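

For the compounds shown here, putting hydrogen in place of fluoro on this aromatic carbon, meta to a large group, gives the first single-point step that lies beyond the scatter in this assay: a 2.5-fold higher number from compound 3 to compound 4 (0.39 log units; beyond the scatter). More compound is needed for the effect once the fluoro group has left, whereas the one earlier step, which added a methoxy group and left the fluoro group in place, did not move the number beyond the scatter. No measurement on record bears on the reason for this step.

From the compounds shown here alone, whether the same change gives a similar step on the core of compound 2, which lacks the added methoxy group, remains open. Also open, going by these compounds, is whether chloro, a nitrile or an amine on this carbon would give a number closer to that of compound 3 or that of compound 4.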